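Aminothiadiazolyl sulfanyl in place of triazolyl sulfanyl

The compounds below may be only part of what the source reports. "The series", "measured", "known", "first", "only" and "open" are said of these compounds alone.

Working notes on a small set of glycoside-linked oxadiazoles. In a functional assay on A549 cells (Homo sapiens) for antiproliferative activity, read by sulforhodamine B assay, with a stated time of 48 h (on this read-out higher numbers stand for weaker inhibition of growth and lower numbers for stronger inhibition of growth), compound 1 `CC(=O)OC[C@H]1O[C@@H](OCc2noc(-c3ccc([N+](=O)[O-])cc3)n2)[C@@H]2OC3(CCCC3)O[C@@H]21` gives 29000 nM, compound 2 `COc1cc(-c2nc(CO[C@@H]3O[C@H](CSc4nnc(N)s4)[C@H]4OC5(CCCC5)O[C@@H]34)no2)cc(OC)c1OC` gives 36000 nM, and compound 3 `O=[N+]([O-])c1ccc(-c2nc(CO[C@@H]3O[C@H](CSc4ncn[nH]4)[C@H]4OC5(CCCC5)O[C@@H]34)no2)cc1` gives 10000 nM. Compound 3 therefore holds the lowest number of the three; the nearest is compound 1 and the furthest compound 2, both beyond the scatter. Within the data shown here, the only single-point step recorded is a 2.9-fold lower number from compound 1 to compound 3 (0.46 log units; beyond the scatter).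

Compound 4 `Nc1nnc(SC[C@H]2O[C@@H](OCc3noc(-c4ccc([N+](=O)[O-])cc4)n3)[C@@H]3OC4(CCCC4)O[C@@H]32)s1` is unmeasured. It differs from compound 3 by 5-amino-1,3,4-thiadiazol-2-yl in place of 1H-1,2,4-triazol-5-yl on a sulfur. Among the measured compounds shown here, no measured step carries this exact change. Compound 2 does carry the entering 5-amino-1,3,4-thiadiazol-2-yl on its sulfur but differs from compound 4 in a second place as well, so its high number cannot be read as a step. For the measured compounds named here, the one recorded step concerns a different exchange at the same sulfur-bearing carbon, so it gives no direction for the present one.

Given this, compound 4 is expected to sit somewhat above compound 3, a step of a 1.8-fold higher number from compound 3 to compound 4 (0.26 log units; within the scatter) in this assay, with wide uncertainty. The estimated value for compound 4 is 18000 nM, with a plausible range from 6000 nM to 55000 nM.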

Compound 4, concentration for 50% growth inhibition: 14000 nM
Beside the measured number, compound 4's estimate is 1.3-fold (0.11 log units) above it; the measured number falls inside the stated range.
By their numbers in this assay, from the lowest: compounds 3 and 4 (each within the scatter of the next); then compounds 1 and 2 (each within the scatter of the next).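

In this assay, the exchange on the sulfur gives a 1.4-fold higher number from compound 3 to compound 4 (0.15 log units; within the scatter), so with the 4-nitrophenyl group held constant, the data do not separate 5-amino-1,3,4-thiadiazol-2-yl from 1H-1,2,4-triazol-5-yl. The acetoxy exchange on the saturated chain carbon now has a second case, a 2.1-fold lower number from compound 1 to compound 4 (0.32 log units; beyond the scatter), alongside a 2.9-fold lower number from compound 1 to compound 3 (0.46 log units; beyond the scatter), and both listed sulfanyl groups go with a lower number than acetoxy, with no listed compound against this. Among these compounds, the aryl exchange can also be read for the first time, as 4-nitrophenyl in place of 3,4,5-trimethoxyphenyl gives a 2.6-fold lower number from compound 2 to compound 4 (0.41 log units; beyond the scatter) with the (5-amino-1,3,4-thiadiazol-2-yl)sulfanyl group held constant, so the high number of compound 2 goes with its 3,4,5-trimethoxyphenyl group in this pair.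

No supporting data bear on the cause of any of these steps. Going by these compounds, it remains open how a primary amine or a carboxylic acid on that saturated chain carbon, or a 4-aminophenyl group on the aromatic carbon, would compare, and whether the aryl step holds with 1H-1,2,4-triazol-5-yl on the sulfur.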